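Series notes: distal aryl substituent, compound 3 to compound 4

A few compounds are considered here, and "the series" means these few. Any claim that something is new, unique, unknown or untested is made for them only; others in the source may bear on it.

Measured so far:
compound 1 `CC[C@H](C)[C@H](N)CN(C(=O)[C@@H]1C[C@H]1c1cccs1)c1ccc(-c2ccccc2)cc1`: 360 nM
compound 2 `CC[C@H](C)[C@H](N)CN(C(=O)[C@@H]1C[C@H]1c1nc(C)cs1)c1ccc(-c2ccccc2)cc1`: 730 nM
compound 3 `CCc1ccc(-c2ccc(N(C[C@@H](N)[C@@H](C)CC)C(=O)[C@@H]3C[C@H]3c3ccccc3)cc2)cc1`: 44 nM

In a functional assay for agonist activity at G protein-coupled receptor 88 (Homo sapiens), read by HTRF and cAMP accumulation (a lower number here means that less compound is needed, a higher number that more compound is needed for the effect), compound 3 gives the lowest number of the three; compound 1 sits an appreciable distance higher and compound 2 higher still, both gaps beyond the scatter. For the measured compounds named here, the only single-point step available is a 2.0-fold higher number from compound 1 to compound 2 (0.31 log units; beyond the scatter), which concerns the group on the saturated ring carbon and says nothing about the distal phenyl ring.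

Compound 4 `CC[C@H](C)[C@H](N)CN(C(=O)[C@@H]1C[C@H]1c1ccccc1)c1ccc(-c2ccc(CNC)cc2)cc1` differs from compound 3 at that distal ring: methylamino in place of methyl on a saturated chain carbon bound to an aromatic carbon. Going by the values given here, no measured pair touches this position, so there is no step to lean on; the expectation is set by the value of compound 3 alone, with a wide range to cover the unknown. The number for compound 4 in this assay is expected to stay near that of compound 3, the estimated step being a 1.8-fold higher number from compound 3 to compound 4 (0.26 log units; within the scatter), with neither direction excluded. Compound 4 is thus estimated at 80 nM, expected to fall between 25 nM and 300 nM.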

Compound 4, half-maximal effective concentration: 6400 nM
Compound 4: middle estimate off by 80-fold (1.90 log units), on the low side, and the stated range ends below it.
By their numbers in this assay, from the lowest: compound 3; then compound 1; then compound 2; then compound 4.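

In this assay, methylamino in place of methyl on a saturated chain carbon bound to an aromatic carbon gives a 150-fold higher number from compound 3 to compound 4 (2.16 log units; beyond the scatter), so this place in the series is far from indifferent to the change. For the compounds shown here, the only earlier step, a 2.0-fold higher number from compound 1 to compound 2 (0.31 log units; beyond the scatter), lies at another place and is much smaller, and no earlier step touched this one. The change adds one nitrogen, one hydrogen-bond donor and one hydrogen-bond acceptor, but nothing measured here bears on why the number rises so steeply.

Still open, from the compounds shown here alone, is whether the step follows the nitrogen itself or the whole methylamino group, which aminomethyl, dimethylaminomethyl or methoxymethyl in the same place would help separate. Also open, going by these compounds, is how a longer alkyl chain such as propyl would read against the 4-ethylphenyl of compound 3.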